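Phenyl Removed from a Benzylamino Group: Expected Inhibition

A few compounds are considered here, and "the series" means these few. Any claim that something is new, unique, unknown or untested is made for them only; others in the source may bear on it.

Compound 1 `Nc1nccc2c1ncn2[C@H]1C[C@H](O)[C@@H](CO)O1`: 18%
Compound 2 `OC[C@H]1OC(n2cnc3c(NCc4ccccc4)nccc32)[C@H](O)[C@@H]1O`: 32%
Compound 3 `[O-][n+]1ccc2[nH]cnc2c1`: 3%

In a functional assay (Homo sapiens) for inhibition of Nucleic Acid, tested at 100 uM (on this read-out lower numbers stand for less inhibition and higher numbers for more inhibition at the one concentration tested (going by the name of the read-out)), compound 2 gives 32%, the highest of the three numbers. Compound 1 gives 18%, a gap beyond the usual scatter, and compound 3 gives 3%, further away still. Compound 4 `CNc1nccc2c1ncn2C1O[C@H](CO)[C@@H](O)[C@H]1O` has not yet been measured. It differs from compound 2 in one place: hydrogen in place of phenyl on a saturated chain carbon bound to a nitrogen on an aromatic ring. Within the data shown here, no step between measured compounds of this kind is available, so the change is judged from the numbers alone. Because compound 1, which also carries no phenyl on its amine, gives 18%, a downward step of modest size is expected. The estimated step is a number 12 percentage points lower from compound 2 to compound 4 (beyond the scatter). Compound 4 is therefore expected to give 20%, most likely between 6% and 34%.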

Compound 4, a percentage reported as inhibition, at one concentration (the size of the read-out at that concentration, not a potency): 8%
Compound 4: middle estimate off by 12 percentage points, on the high side; the range from low to high includes it.
By their numbers in this assay, from the lowest: compounds 3, 4 and 1 (each within the scatter of the next, the first and the last beyond it); then compound 2.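

In this assay, among these compounds, cutting benzylamino back to methylamino gives a number 24 percentage points lower from compound 2 to compound 4 (beyond the scatter), the first direct reading of a single change at this position. It shows that the phenyl on this saturated chain carbon counts for the inhibition seen, since removing it alone moves the number beyond the scatter. Nothing at hand explains the drop.

Still open, on these data alone, is whether the phenyl ring itself matters or whether any larger group would serve. A longer chain such as butyl, a cyclohexyl ring in place of the phenyl, or a phenyl carrying a methoxy group would help separate these possibilities.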